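A few compounds are considered here, and "the series" means these few. Any claim that something is new, unique, unknown or untested is made for them only; others in the source may bear on it.

Measured so far in an ADME assay on the whole organism (Rattus norvegicus) for pharmacokinetics, at a dose of 1 mg/kg by the oral route; a lower number here means that a smaller share of the oral dose reaches the circulation, a higher number that a larger share of the oral dose reaches the circulation:
- compound 1 `COc1ccc(F)cc1-c1ccnc2[nH]c(C3=CCN([C@H]4CC[C@@H](C(=O)O)CC4)CC3)cc12`: 20%
- compound 2 `COc1ccc(F)cc1-c1c(F)cnc2[nH]c(C3=CCN([C@H]4CC[C@H](C(=O)O)CC4)CC3)cc12`: 28%

Going by the values given here, compound 2 stands within the scatter of compound 1, so these two values set no order between the compounds. The next compound to be measured is compound 3 `COc1ccc(F)cc1-c1c(F)cnc2[nH]c(C3=CCN([C@H]4CC[C@@H](C(=O)O)CC4)CC3)cc12`. Its relation to compound 2 is: the two compounds have the same atoms and bonds and differ only in configuration as drawn: 2 of 2 stereo elements differ (all stereocentres are inverted: mirror images); a stereocentre at a saturated ring carbon is drawn r in compound 2 and s in compound 3; a stereocentre at a saturated ring carbon is drawn r in compound 2 and s in compound 3. Nothing leaves and nothing enters, and only the configuration as drawn at the two saturated ring carbons differs.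

Among the compounds with values here, no measured pair differs in this way alone, so the data offer no direct guide to the size of this change. The expectation therefore rests on the two available values: compound 1 gives 20% and compound 2 gives 28%. No direction is favoured, and no step beyond the scatter is expected. The expected step of a number 3 percentage points lower from compound 2 to compound 3 (within the scatter) is a working estimate and is small beside that scatter. The estimated value in this assay for compound 3 is 25%, with an expected range of 12% to 40%.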

Compound 3, oral bioavailability: 13%
The estimate for compound 3 lay 12 percentage points above the measured number; the measured number falls inside the stated range.
By their numbers in this assay, from the lowest: compounds 3, 1 and 2 (each within the scatter of the next, the first and the last beyond it).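

In this assay, the configuration at the two saturated ring carbons now proves to matter on its own: a number 15 percentage points lower from compound 2 to compound 3 (beyond the scatter). With atoms and bonds unchanged, this step can be assigned only to the two stereocentres, because nothing else separates the pair: the fact that compounds 2 and 3 differ only in the configuration as drawn. Fluoro in place of hydrogen on an aromatic carbon, read with the configuration held constant, gives a number 7 percentage points lower from compound 1 to compound 3 (within the scatter), so this single change does not stand clear of the scatter in this pair, and the inversion of configuration is the only single change so far with a step beyond it.

Going by these compounds alone, whether the configuration of compound 2 would give a comparable step without the fluoro stays open, as the series holds only one mirror-image pair. Also open, going by these compounds, is how this assay responds when a primary amide or a tetrazole takes the place of the carboxylic acid.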